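Swapping Butylamino for Diethylamino on a Shared Core

The source may report more compounds than this note shows. Statements on the series, on what has been measured and on what is new or still open speak of the compounds shown alone.

Of the compounds shown here, three built on one core have been measured in a functional assay on the whole organism with Rattus norvegicus as the target; a lower number here means that less compound is needed, a higher number that more compound is needed for the effect. Compound 1 `CCOC(=O)C(=O)Nc1cccc(N(C)C)c1C#N` gives 0.2 mg/kg. Compound 2 `CCOC(=O)C(=O)Nc1cccc(NC)c1C#N` gives 0.2 mg/kg, and the change between them was no change at the digits printed from compound 1 to compound 2 (within the scatter). Compound 3 `CCCCNc1cccc(NC(=O)C(=O)OCC)c1C#N` gives 0.3 mg/kg; its distance from the others is described by a 1.5-fold higher number from compound 1 to compound 3 (0.18 log units; within the scatter) and a 1.5-fold higher number from compound 2 to compound 3 (0.18 log units; within the scatter), so all three numbers sit within the scatter of one another.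

Compound 4 `CCOC(=O)C(=O)Nc1cccc(N(CC)CC)c1C#N` is not yet measured. It differs from compound 3 as follows: diethylamino in place of butylamino on an aromatic carbon. The same atoms are present, only joined differently, and a hydrogen-bond donor is lost. The nearest precedents are the removal of a methyl from a ring nitrogen, no change at the digits printed from compound 1 to compound 2 (within the scatter), and the exchange of dimethylamino for butylamino, a 1.5-fold higher number from compound 1 to compound 3 (0.18 log units; within the scatter), both within the scatter. Among the measured compounds shown here, no step at this position has moved the number beyond the scatter, so the expected step for compound 4 is a 1.2-fold lower number from compound 3 to compound 4 (0.08 log units; within the scatter), none beyond the scatter. Compound 4 is therefore estimated to give 0.25 mg/kg, within a range of 0.12 mg/kg to 0.5 mg/kg.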

Compound 4, dose for half-maximal effect: 0.7 mg/kg
Beside the measured number, compound 4's estimate is 2.8-fold (0.45 log units) below it; the measured number lies above the stated range.
By their numbers in this assay, from the lowest: compounds 1, 2 and 3 (each within the scatter of the next); then compound 4.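

In this assay, this position shows its first step beyond the scatter: putting diethylamino in place of butylamino, two groups made of the same atoms, gives a 2.3-fold higher number from compound 3 to compound 4 (0.37 log units; beyond the scatter). Diethylamino also stands apart from the smaller groups, with a 3.5-fold higher number from compound 1 to compound 4 (0.54 log units; beyond the scatter) and a 3.5-fold higher number from compound 2 to compound 4 (0.54 log units; beyond the scatter), so the arrangement of the carbons on this nitrogen matters, not just their number. Losing the hydrogen on that nitrogen does not by itself go with a higher number, since the dimethylamino group of compound 1 is likewise fully substituted, and no measurement here offers an explanation for the rise.

The compounds shown leave open whether ethylamino would stay with the lower group or whether dipropylamino would climb further. A ring amine such as pyrrolidine, which ties the two chains together, also remains an open case at this position.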